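Removing a tert-butoxycarbonyl group: two pairs on two cores

The source may hold more compounds than are shown below. What is called first, only, known or untested is meant among the compounds shown, and "the series" means these compounds.

Measured compounds:
- compound 1, `C[C@H](NC(=O)c1cc(Cl)ccc1OCCNC(=O)OC(C)(C)C)C(=O)Nc1ccc([N+](=O)[O-])cc1Cl`, gives > 10000 nM in a functional assay on MDA-MB-231 cells (Homo sapiens) for inhibition, read by MTT assay, with a stated time of 72 h; on this read-out lower numbers stand for stronger inhibition and higher numbers for weaker inhibition; this value is a limit of the assay.
- compound 2, `C[C@H](NC(=O)c1cc(Cl)ccc1OCCN)C(=O)Nc1ccc([N+](=O)[O-])cc1Cl`, gives > 10000 nM in this assay; this value too is a limit of the assay.
- compound 3, `CC(C)(C)OC(=O)NCCOc1ccc(Cl)cc1C(=O)NCC(=O)Nc1ccc2c(c1)S(=O)(=O)C=C2`, gives 2080 nM in this assay.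

Compound 1 and compound 2 share one core and differ in a single place, (hydrogen in place of tert-butoxycarbonyl on an amine nitrogen). The step that the two limits leave unreadable from compound 1 to compound 2 cannot be read because of the limit of > 10000 nM in this assay, at which 2 of the 3 values shown sit. Compound 3 stands on a different core, and the difference between the two cores is not broken down here; compound 3 is the only one of the three with a number rather than a limit.

Compound 4, `NCCOc1ccc(Cl)cc1C(=O)NCC(=O)Nc1ccc2c(c1)S(=O)(=O)C=C2`, has not yet been measured. It differs from compound 3 by hydrogen in place of tert-butoxycarbonyl on an amine nitrogen, the same change that separates compound 1 from compound 2, occurring twice among these compounds. The earlier pair gives no readable size for this change, so the expectation for compound 4 rests mainly on the value of compound 3 and on the change itself. Compound 4 is expected to lie near compound 3, with a step of about a 1.4-fold higher number from compound 3 to compound 4 (0.16 log units; within the scatter), wide on both sides given how little the earlier pair tells. The estimate for compound 4 in this assay is 3000 nM, expected to fall between 800 nM and 10000 nM.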

Compound 4, half-maximal inhibitory concentration: 6370 nM
Compound 4: the middle estimate sits 2.1-fold (0.33 log units) below what was measured, within the range that was stated.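

On the core of compound 3, replacing tert-butoxycarbonyl with hydrogen on the amine nitrogen gives a 3.1-fold higher number from compound 3 to compound 4 (0.49 log units; beyond the scatter) in this assay, so of this pair the compound carrying the free 2-aminoethyl chain is the weaker inhibitor, by a modest margin. On the core of compound 1 the same change cannot be read, because both partners of that pair sit at a limit of the assay and neither gives a number: the limit of > 10000 nM in this assay, at which 2 of the 4 values shown sit. The size of the change is therefore known on one core only, so the data neither confirm nor contradict that it carries from one core to the other, and a single readable step sets no pattern for the series.

The compounds shown leave open how other groups on this amine nitrogen, such as an acetyl or a methyl group, would read on the core of compound 3, and whether a chain longer than 2-aminoethyl would move the result in either direction. Also open, from the compounds shown here alone, is whether a carboxylic acid in place of the amine at the end of the chain would bring the core of compound 1 off its limit and give it a readable number.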